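A Chloro Substituent and Clearance in Rat Liver Microsomes

A few compounds are considered here, and "the series" means these few. Any claim that something is new, unique, unknown or untested is made for them only; others in the source may bear on it.

Compound 1 `CN1CC(=O)N/C1=N\C(=O)Nc1ccncc1` and compound 2 `CN1CC(=O)N/C1=N\C(=O)Nc1ccccn1` are built from the same atoms joined differently; the difference between the two cores is not broken down here. In an in vitro ADME assay on microsomes from liver (Rattus norvegicus) for metabolic stability (a lower number here means slower removal, a higher number faster removal of the compound), compound 1 gives 9 mL.min-1.g-1, and compound 2 gives 22 mL.min-1.g-1. Compound 3 `CN1CC(=O)N/C1=N\C(=O)Nc1ccncc1Cl` carries chloro in place of hydrogen on an aromatic carbon, and in this assay compound 3 gives 31 mL.min-1.g-1, which amounts to a 3.4-fold higher number from compound 1 to compound 3 (0.54 log units; beyond the scatter). Compound 4 `CN1CC(=O)N/C1=N\C(=O)Nc1ncccc1Cl` has not yet been measured; it differs from compound 2 by chloro in place of hydrogen on an aromatic carbon. The place of the change is described in the same words for both pairs, so this is the same change made on a second core. Resting on a 3.4-fold higher number from compound 1 to compound 3 (0.54 log units; beyond the scatter), a step of similar size is expected: a 3.0-fold higher number from compound 2 to compound 4 (0.47 log units; beyond the scatter). Compound 4 is thus expected to give 65 mL.min-1.g-1 in this assay, with a likely span from 28 mL.min-1.g-1 to 150 mL.min-1.g-1.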

Compound 4, intrinsic clearance in microsomes: 53 mL.min-1.g-1
The estimate for compound 4 lay 1.2-fold (0.09 log units) above the measured number, and the stated range covers the measured number.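

In this assay, chloro in place of hydrogen on an aromatic carbon gives a 2.4-fold higher number from compound 2 to compound 4 (0.38 log units; beyond the scatter) and so moves the number in the same direction as on the core of compound 1. The two steps match in direction, and the gap between their sizes is no larger than ordinary scatter: the same change on two cores in this assay, a 3.4-fold higher number (0.54 log units; beyond the scatter) from compound 1 to compound 3 and a 2.4-fold higher number (0.38 log units; beyond the scatter) from compound 2 to compound 4, 1.4-fold (0.16 log units) apart, within the scatter of two such steps. The change therefore carried over between these two cores in this one assay, but two pairs make no general rule and do not explain why removal is faster.

Going by these compounds, whether fluoro, a methoxy group or an amine in the same place would shift the number similarly remains open. So does whether chloro would behave this way on any other core.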